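The compounds below may be only part of what the source reports. "The series", "measured", "known", "first", "only" and "open" are said of these compounds alone.

Measured compounds:
- compound 1, `COCOc1cc(O)ccc1/C=C/C(=O)c1ccc(O)cc1O`: "not determined" (no result reported) in a functional assay on NCI-H460 cells (Homo sapiens) for inhibition, read by sulforhodamine B assay, with a stated time of 48 h; a lower number here means a stronger inhibitor of growth, a higher number a weaker inhibitor of growth
- compound 2, `COc1ccc(/C=C/C(=O)c2ccc(O)cc2O)c(OC)c1`: 37000 nM

Compound 2 stands alone on the numbers shown: it is the only compound with a value in this assay, and compound 1 appears only as an entry without a single number, so nothing can be said about where compound 2 falls relative to any other measured compound.

Compound 3 is `COc1cc(OC)c(OC)cc1/C=C/C(=O)c1ccc(O)cc1O`. Compared with compound 2, the change is methoxy in place of hydrogen on an aromatic carbon. Within the data shown here, no step between two measured compounds is available to show what such a change does to the growth inhibition concentration here, so the expectation rests on the single value of compound 2 alone. The account therefore expects a step in this assay that is small, if any, and not clearly beyond the usual scatter of repeated measurements, with no firm direction.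

For compound 3 the estimate in this assay is 30000 nM, with a range from 10000 nM to 90000 nM. This estimate means a step of a 1.2-fold lower number from compound 2 to compound 3 (0.09 log units; within the scatter), expected to lie within the scatter.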

Compound 3, concentration for 50% growth inhibition: 60000 nM
Compound 3: the middle estimate sits 2.0-fold (0.30 log units) below what was measured; low and high end bracket the measured number.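

Among these compounds, the step gives the first reading of what a substituent does at this position: in this assay, methoxy in place of hydrogen on an aromatic carbon, at the place ortho to a methoxy group and para to a methoxy group, gives a 1.6-fold higher number from compound 2 to compound 3 (0.21 log units; within the scatter). Compound 2 and compound 3 therefore cannot be told apart in this read-out, and the position takes this methoxy, with its 2 heavy atoms and 1 hydrogen-bond acceptor, without a change that stands out from repeated measurement. No measurement shown here speaks to the reason for this result.

The compounds shown say nothing about an amine, a carboxylic acid or a longer chain such as ethoxy at this position, so it remains open whether the same holds for any group other than methoxy. Also open, going by these compounds, is whether methoxy would give a similar step elsewhere on this ring, or on a parent compound more potent than compound 2, which stands at 37000 nM.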